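Amide aryl variation in a small antiproliferative series

The compounds below may be only part of what the source reports. "The series", "measured", "known", "first", "only" and "open" are said of these compounds alone.

Measured so far:
compound 1 `COC(=O)c1scc(-c2ccc(NC(=O)c3ccc(OC)nc3)cc2)c1OC`: 18300 nM
compound 2 `COC(=O)c1scc(-c2ccc(NC(=O)c3cccc(C(F)(F)F)c3)cc2)c1OC`: 6130 nM

Both numbers come from a functional assay on K562 cells (Homo sapiens) for antiproliferative activity, read by MTT assay, with a stated time of 24 h; a lower number here means a stronger inhibitor, a higher number a weaker inhibitor. For the measured compounds named here, compound 1 stands highest of the two; the only measured step is a 3.0-fold lower number from compound 1 to compound 2 (0.47 log units; beyond the scatter), a modest shift beyond the scatter. On these data alone, compound 3 `COC(=O)c1scc(-c2ccc(NC(=O)c3ccccn3)cc2)c1OC` is untested and differs from compound 1 in pyridin-2-yl in place of 6-methoxypyridin-3-yl on a carbonyl carbon. Going by the values given here, no measured step changes the amide aryl group in this way, so the one step available bears only loosely, and no step beyond the scatter is expected in this assay. Compound 3 is estimated at 15000 nM, with a range of 5000 nM to 45000 nM. This estimate is expected to mean a 1.2-fold lower number from compound 1 to compound 3 (0.09 log units; within the scatter).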

Compound 3, half-maximal inhibitory concentration: 24200 nM
Compound 3: middle estimate off by 1.6-fold (0.21 log units), on the low side; the range from low to high includes it.
By their numbers in this assay, from the lowest: compound 2; then compounds 1 and 3 (each within the scatter of the next).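

In this assay, pyridin-2-yl in place of 6-methoxypyridin-3-yl on the carbonyl carbon gives a 1.3-fold higher number from compound 1 to compound 3 (0.12 log units; within the scatter) and so does not separate these two groups. Pyridin-2-yl in place of 3-(trifluoromethyl)phenyl gives a 3.9-fold higher number from compound 2 to compound 3 (0.60 log units; beyond the scatter) and places compound 2 beyond the scatter of both other compounds at this position. No available evidence bears on this result.

Still open, on these data alone, is how a plain phenyl group or an aminophenyl group would compare on the same carbonyl carbon. The compounds shown also leave open whether the gap for 3-(trifluoromethyl)phenyl persists on another core.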